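Aryl amide swap on a shared diazabicyclic core

This account rests on a few compounds, and the source may have more. Where it says the series, first, only, none or still open, it means among the compounds named here.

Among the measured compounds shown here, compound 2 `O=C(Nc1ccc(Cl)cc1)c1cncc(N2CC3CC(C2)N3)c1` is the weaker of the two compounds measured so far in an assay on membranes from Cerebral cortex for displacement of a labelled ligand from Neuronal acetylcholine receptor; alpha4/beta2 (Rattus norvegicus) (a higher number here means a weaker inhibitor, a lower number a stronger inhibitor), where compound 2 gives 0.404 nM; compound 1 `O=C(Nc1ccc(F)cc1F)c1cncc(N2CC3CC(C2)N3)c1` gives 0.051 nM. For the measured compounds named here, the one step available, a 7.9-fold higher number from compound 1 to compound 2 (0.90 log units; beyond the scatter), was a modest rise that followed a change of the aryl group on the amide nitrogen. Compound 3 `CCc1cccc(NC(=O)c2cncc(N3CC4CC(C3)N4)c2)c1` differs from compound 2 by 3-ethylphenyl in place of 4-chlorophenyl on an amide-type nitrogen. Going by the values given here, no measured step involves a 3-ethylphenyl group, so the earlier step bears only loosely on this change: it shows that the aryl group on the amide nitrogen can move the number by a modest amount. A further modest change in either direction, or none beyond the scatter, is therefore expected, and the estimate for compound 3 in this assay is 0.8 nM, within 0.15 nM to 4 nM, meaning an expected step of a 2.0-fold higher number from compound 2 to compound 3 (0.30 log units; within the scatter).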

Compound 3, inhibition constant: 1.3 nM
The estimate for compound 3 lay 1.6-fold (0.21 log units) below the measured number; measured number inside the range.
By their numbers in this assay, from the lowest: compound 1; then compound 2; then compound 3.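

Within this assay, 3-ethylphenyl on the amide-type nitrogen gives a 3.2-fold higher number from compound 2 to compound 3 (0.51 log units; beyond the scatter), so a second change of aryl group, here to one with carbon atoms only, again moves the number beyond the scatter. The full span now reaches a 25-fold higher number from compound 1 to compound 3 (1.41 log units; beyond the scatter), a large step where the first pair showed only a modest one, and it arises with the shared core unchanged. Even so, compound 3, the highest of the three, still gives 1.3 nM.

The compounds shown leave open whether the rise from compound 2 to compound 3 follows the change of group or the change of its ring position, a question that a 3-chlorophenyl or 4-ethylphenyl group on the same nitrogen would address. No measurement here accounts for the differences among the three aryl groups.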